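Rearranging the Exocyclic Substituent on the Shared Core

This account rests on a few compounds, and the source may have more. Where it says the series, first, only, none or still open, it means among the compounds named here.

Compound 1 `Cc1ccc(CN2C(=O)S/C(=C\c3ccc(O)cc3)C2=O)cc1`: in a functional assay on the whole organism (plasma) with Mus musculus as the target, with a stated time of 15 days, at a dose of 30 mg/kg by the oral route (on this read-out lower numbers stand for a weaker effect and higher numbers for a stronger effect at the one dose given), compound 1 gives 37.3%.
Compound 2 `COc1ccc(/C=C2\SC(=O)N(Cc3ccc(C)cc3)C2=O)cc1`: in this assay compound 2 gives 50.8%.

Within the data shown here, compound 2 stands highest of the two numbers measured so far; its nearest neighbour is compound 1, and the step of a number 13.5 percentage points higher from compound 1 to compound 2 (beyond the scatter) lies beyond the scatter of repeated measurements. Compound 3 `Cc1ccc(CN2C(=O)S/C(=C\OCc3ccccc3)C2=O)cc1` has not yet been measured in this assay. It differs from compound 2 by benzyloxy in place of 4-methoxyphenyl on a double-bonded chain carbon bound to a double-bonded ring carbon. Among the measured compounds shown here, the one measured step, a number 13.5 percentage points higher from compound 1 to compound 2 (beyond the scatter), concerns a methyl in place of hydrogen on an oxygen on an aromatic ring; it does not touch the double-bonded chain carbon where compound 3 changes, and no measured pair shows what follows when 4-methoxyphenyl gives way to benzyloxy at that place. For the measured compounds named here, no measured step therefore bears directly on this change, and the expectation rests on the small range of numbers seen so far rather than on a matching precedent. Compound 3 is expected to give about 33% in this assay, with a range from 12% to 54%. This estimate corresponds to an expected step of a number 17.8 percentage points lower from compound 2 to compound 3 (beyond the scatter), a downward move, although the upper end of the range would leave compound 3 within the scatter of compound 2.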

Compound 3, a percentage reported as activity, at one dose (the size of the read-out at that dose, not a potency): 20.2%
Beside the measured number, compound 3's estimate is 12.8 percentage points above it, and the stated range covers the measured number.
By their numbers in this assay, from the lowest: compound 3; then compound 1; then compound 2.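

Among these compounds, the change at the double-bonded chain carbon bound to a double-bonded ring carbon has a larger effect in this assay than the one earlier step on the aromatic oxygen: the result is a number 30.6 percentage points lower from compound 2 to compound 3 (beyond the scatter), and the comparison with the free phenol gives a number 17.1 percentage points lower from compound 1 to compound 3 (beyond the scatter). Since 4-methoxyphenyl and benzyloxy hold the same atoms joined differently, with the same counts of heavy atoms, donors and acceptors, this read-out responds to how the atoms are arranged at this place and not only to what they are, and compound 3 is the weakest of the three. Nothing available explains why the arrangement with benzyloxy gives the lower number.

Among the compounds shown here, with only one group of this kind at this place, it remains open whether the loss follows from the oxygen sitting directly on the chain carbon or from the ring being carried on a flexible link, which a plain benzyl group there could help to separate. As far as these compounds go, it is also open how a carboxylic acid or an amine on the benzyloxy ring, or a longer chain such as 2-phenylethoxy, would read in this assay.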